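The compounds below may be only part of what the source reports. "The series", "measured", "known", "first", "only" and "open" are said of these compounds alone.

Compound 1 `COc1ccc(OC)c(/C=C/c2nnc(Nc3ccc(Cl)cc3)o2)c1` and compound 2 `COc1ccc(OC)c(/C=C/C(=O)N/N=C/c2ccc(Cl)cc2)c1` were both tested in a functional assay on 786-0 cells (Homo sapiens) for antiproliferative activity, read by sulforhodamine B assay, with a stated time of 48 h; a lower number here means a stronger inhibitor of growth, a higher number a weaker inhibitor of growth. Compound 1 gives 7600 nM in this assay. For compound 2 only a limit of the assay is known: in this assay compound 2 gives > 100000 nM, which is the limit of > 100000 nM in this assay, at which 1 of the 2 values shown sits. Compound 3 `COc1ccc(OC)c(/C=C/C(=O)N/N=C/c2ccccc2)c1` differs from compound 2 by hydrogen in place of chloro on an aromatic carbon. No step of this kind has been measured among the compounds shown. The expected change is a number no higher from compound 2 to compound 3 (the limit leaves the size open), nothing beyond the scatter. Compound 3 is therefore estimated at 100000 nM, within a range from 30000 nM to 300000 nM, and is most likely to be reported again only as a limit.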

Compound 3, concentration for total growth inhibition: 72500 nM
Compound 3: middle estimate off by 1.4-fold (0.14 log units), on the high side, within the range that was stated.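

Compound 3, with hydrogen in place of chloro, gives 72500 nM as a true reading rather than a limit, so this aromatic carbon can carry hydrogen and still give a measurable value. The change from chloro to hydrogen is a small step at minimum (an at least 1.3-fold lower number from compound 2 to compound 3 (0.13 log units; that floor lies within the scatter)), so no effect of the chloro can yet be claimed. Its real size stays unknown because compound 2 has only a limit: the limit of > 100000 nM in this assay, at which 1 of the 3 values shown sits.

On these data alone, what a methoxy group or an amine on this same carbon would give remains open.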